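A third methoxy on the benzylamine side chain

The compounds below may be only part of what the source reports. "The series", "measured", "known", "first", "only" and "open" are said of these compounds alone.

Three compounds share one core and differ only in the group carried on the side chain. Compound 1 `Nc1cc(N)c2nc(-c3ccccc3)c(Oc3ccc(Cl)c(Cl)c3)nc2c1` gives 3020 nM in a functional assay on PC-3 cells (Homo sapiens) for inhibition, read by sulforhodamine B assay, with a stated time of 48 h; on this read-out lower numbers stand for stronger inhibition of growth and higher numbers for weaker inhibition of growth. Compound 2 `Nc1cc(N)c2nc(-c3ccccc3)c(NCc3ccc(Cl)c(Cl)c3)nc2c1` gives 1740 nM, while compound 3 `COc1ccc(CNc2nc3cc(N)cc(N)c3nc2-c2ccccc2)cc1OC` gives 8320 nM, the highest of the three numbers, so it is the weakest inhibitor of growth in this assay. For the measured compounds named here, the only single-change step measured is a 4.8-fold higher number from compound 2 to compound 3 (0.68 log units; beyond the scatter). Compound 4 `COc1cc(CNc2nc3cc(N)cc(N)c3nc2-c2ccccc2)cc(OC)c1OC` differs from compound 3 by methoxy in place of hydrogen on an aromatic carbon. Going by the values given here, no measured step tests adding one more methoxy, and the one step available concerns a different exchange, so I expect little change, perhaps a slightly higher number. Compound 4 is therefore expected near 10000 nM, within 4000 nM to 25000 nM, which would mean a 1.2-fold higher number from compound 3 to compound 4 (0.08 log units; within the scatter).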

Compound 4, concentration for 50% growth inhibition: 2190 nM
Compound 4: the middle estimate sits 4.6-fold (0.66 log units) above what was measured, outside the stated range (below it).
By their numbers in this assay, from the lowest: compounds 2, 4 and 1 (each within the scatter of the next); then compound 3.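

Methoxy in place of hydrogen on this aromatic carbon gives a 3.8-fold lower number from compound 3 to compound 4 (0.58 log units; beyond the scatter) in this assay, so growth inhibition becomes stronger. The earlier compounds shown here showed only an exchange of chlorine-bearing for methoxy-bearing side chains, whereas this step shows that one added methoxy at this position can itself shift the number. No available evidence explains the shift.

On these data alone, what stays open is whether the gain is specific to methoxy. Ethoxy, hydroxyl or an amine on the same aromatic carbon would test this.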